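The compounds below may be only part of what the source reports. "The series", "measured", "known", "first", "only" and "open" are said of these compounds alone.

The series is followed in a functional assay for inhibition, with Homo sapiens as the target; on this read-out higher numbers stand for weaker inhibition and lower numbers for stronger inhibition. Compound 1 `CCCc1nc(C)c2c(C(C)C)nnc(SC)n12` is reported there only as a limit, > 48000 nM. Compound 2 `CCCc1nc(C)c2cnnc(NCCN(C)C)n12` likewise gives only a limit in this assay, > 48000 nM. Both compounds thus stand at the limit of > 48000 nM in this assay, at which 2 of the 2 values shown sit, so no number is known for either, and compound 2 cannot be placed against compound 1 beyond that. Compound 3 `CCCc1nc(C)c2cnnc(SC)n12` is not yet measured in this assay. It differs from compound 2 by methylsulfanyl in place of (2-(dimethylamino)ethyl)amino on an aromatic carbon. Going by the values given here, no step between measured compounds is available to indicate what size of change this swap brings. With compound 2 at a limit, the expected step that the limit leaves unreadable from compound 2 to compound 3 is none beyond the scatter, and the most likely outcome is again a limit rather than a number. Compound 3 is estimated in this assay at 60000 nM, ranging from 20000 nM to 200000 nM.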

Compound 3, half-maximal inhibitory concentration: > 48000 nM
Compound 3 ended at the assay's limit (the forecaster's own chance of this, stated with the estimate: 85%); the middle value does not contradict the limit.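

No step can be read among compound 1, compound 2 and compound 3 in this assay, as all three give only a limit: the limit of > 48000 nM in this assay, at which 3 of the 3 values shown sit. The compounds shown leave open which change on the shared core, if any, would bring a measurable value in this assay.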